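The source may hold more compounds than are shown below. What is called first, only, known or untested is meant among the compounds shown, and "the series" means these compounds.

Compounds measured so far, with their values in a functional assay on A549 cells (Homo sapiens) for antiproliferative activity, read by MTT assay, with a stated time of 48 h; a higher number here means a weaker inhibitor, a lower number a stronger inhibitor:

- compound 1, `CCOc1ccc(C(=O)/C=C/c2c(/C=C/c3ccc(OC)cc3)cc(OC)cc2OC)cc1`: 7.5 ug/mL
- compound 2, `CCCCCCOc1ccc(C(=O)/C=C/c2c(/C=C/c3ccc(OC)cc3)cc(OC)cc2OC)cc1`: 8.4 ug/mL
- compound 3, `COc1ccc(/C=C/c2cc(OC)cc(OC)c2/C=C/C(=O)c2ccc(F)cc2)cc1`: 6.6 ug/mL

Compound 2 carries nominally the highest of the three numbers, but it is separated from neither neighbour by more than the scatter: one of the two steps is a 1.1-fold higher number from compound 1 to compound 2 (0.05 log units; within the scatter) and the other is a 1.3-fold lower number from compound 2 to compound 3 (0.10 log units; within the scatter). Compound 3 against compound 1 gives a 1.1-fold lower number from compound 1 to compound 3 (0.06 log units; within the scatter), so the three sit together.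

The next compound in the series is compound 4, `CCCCCCCCCCCCOc1ccc(C(=O)/C=C/c2c(/C=C/c3ccc(OC)cc3)cc(OC)cc2OC)cc1`. Relative to compound 2 the change is hexyl in place of hydrogen on a saturated chain carbon, six bonds along the chain from an oxygen on an aromatic ring.

Within the data shown here, the only measured step that bears on this is the one from compound 1 to compound 2, where a longer chain on the same aromatic oxygen gave a 1.1-fold higher number from compound 1 to compound 2 (0.05 log units; within the scatter), within the scatter. Going from compound 2 to compound 4 lengthens the same chain again, and there is nothing in these data to suggest the number would move beyond the scatter, in either direction; if anything, a small further rise like the earlier one would fit. Compound 4 is therefore expected to give about 9.5 ug/mL in this assay, with a range from 5 ug/mL to 19 ug/mL. The step this estimate implies, a 1.1-fold higher number from compound 2 to compound 4 (0.05 log units; within the scatter), is expected to lie within the scatter.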

Compound 4, half-maximal inhibitory concentration: 7.9 ug/mL
Estimate against measurement, compound 4: 1.2-fold (0.08 log units) above, within the range that was stated.
By their numbers in this assay, from the lowest: compounds 3, 1, 4 and 2 (each within the scatter of the next).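

In this assay, hexyl in place of hydrogen on the saturated chain leaves the number within the scatter (a 1.1-fold lower number from compound 2 to compound 4 (0.03 log units; within the scatter)), and the full extension, decyl in place of hydrogen, does the same (a 1.1-fold higher number from compound 1 to compound 4 (0.02 log units; within the scatter)). The earlier compounds shown here tested only a single extension of the chain on the aromatic oxygen; the series now has three chain lengths, in compounds 1, 2 and 4, with no step among them beyond the scatter, so this position accepts a far larger saturated chain without a readable change, and no direction with chain length can be drawn from these three compounds. Nothing in hand gives a reason for this flat response.

As far as these compounds go, a chain longer than that of compound 4 remains open, as does whether the flat response would hold with an amine or a carboxylic acid carried on the chain. With every compound shown lying within the scatter of the others, it also stays open which kind of group, if any, would move the number at this position beyond the scatter.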